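Fluoro in place of trifluoromethyl on compound 2

This account rests on a few compounds, and the source may have more. Where it says the series, first, only, none or still open, it means among the compounds named here.

In a functional assay on MCF7 cells (Homo sapiens) for cytotoxicity, read by MTT assay, with a stated time of 24 h (a higher number here means a weaker inhibitor, a lower number a stronger inhibitor), compound 1 `CCNc1cc(-c2ccc(NC(=O)Nc3cccc(Cl)c3)cc2C)ccn1` gives 4180 nM, compound 2 `CCNc1cc(-c2ccc(NC(=O)Nc3cccc(Cl)c3)cc2C(F)(F)F)ccn1` gives 1240 nM and compound 3 `CCNc1cc(-c2ccc(NC(=O)Nc3c(C)cccc3C)cc2C(F)(F)F)ccn1` gives 6950 nM. Compound 2 therefore has the lowest number of the three. Compound 4 `CCNc1cc(-c2ccc(NC(=O)Nc3cccc(Cl)c3)cc2F)ccn1` carries one change from it: fluoro in place of trifluoromethyl on an aromatic carbon. The closest evidence is a 3.4-fold lower number from compound 1 to compound 2 (0.53 log units; beyond the scatter), a modest step with trifluoromethyl in place of methyl, so the same group is involved. The other measured step, a 5.6-fold higher number from compound 2 to compound 3 (0.75 log units; beyond the scatter), changes 3-chlorophenyl and bears little on this question. A modest rise is expected, a 2.2-fold higher number from compound 2 to compound 4 (0.34 log units; beyond the scatter), in this assay. The estimate for compound 4 is 2700 nM, with an expected range of 1100 nM to 6500 nM.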

Compound 4, half-maximal inhibitory concentration: 6940 nM
Compound 4: middle estimate off by 2.6-fold (0.41 log units), on the low side; measured number outside the range, above it.
By their numbers in this assay, from the lowest: compound 2; then compounds 1, 4 and 3 (each within the scatter of the next).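

In this assay, replacing trifluoromethyl with fluoro gives a 5.6-fold higher number from compound 2 to compound 4 (0.75 log units; beyond the scatter), so the lower number at this position goes with trifluoromethyl specifically, not with any small substituent. Fluoro and methyl do not separate here, with a 1.7-fold higher number from compound 1 to compound 4 (0.22 log units; within the scatter). No measurement available here explains why trifluoromethyl stands apart from these two groups.

Still open, as far as these compounds go, is whether chloro, methoxy or nitrile at this position would follow trifluoromethyl or group with fluoro and methyl. Also open, from the compounds shown here alone, is whether the same change keeps its size with 2,6-dimethylphenyl in place of 3-chlorophenyl.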